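Distal amide reversal on the cyclohexyl oxime series

The source may report more compounds than this note shows. Statements on the series, on what has been measured and on what is new or still open speak of the compounds shown alone.

Compound 1 `O=C(Nc1ccccc1)[C@H]1CC[C@H](C(=O)/C(=N/O)Nc2ccc(F)c(Br)c2)CC1`: 150 nM
Compound 2 `O=C(/C(=N/O)Nc1ccc(F)c(Br)c1)C1CCN(S(=O)(=O)Nc2ccccc2)CC1`: 98 nM
Compound 3 `O=C(/C(=N/O)Nc1ccc(F)c(Br)c1)C1CCN(C(=O)c2ccccc2)CC1`: 106 nM

In an assay for inhibition of Indoleamine 2,3-dioxygenase 1 (Homo sapiens), with a stated time of 1 h (on this read-out lower numbers stand for stronger inhibition and higher numbers for weaker inhibition), compound 1 gives the highest of the three numbers, yet its gaps to compound 3 and to compound 2 both fall within the scatter, so no order among the three can be read from these values. For the measured compounds named here, the one measured single-point change, a 1.1-fold higher number from compound 2 to compound 3 (0.03 log units; within the scatter), swaps the group on the ring nitrogen of the shared core and leaves the number unchanged within the scatter.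

Compound 4 `O=C(NC[C@H]1CC[C@H](C(=O)/C(=N/O)Nc2ccc(F)c(Br)c2)CC1)c1ccccc1` differs from compound 1 in one place: benzamidomethyl in place of phenylcarbamoyl on a saturated ring carbon. Going by the values given here, no measured pair shows this exact exchange. Among the compounds with values here, the only related evidence is a 1.1-fold higher number from compound 2 to compound 3 (0.03 log units; within the scatter), which indicates that exchanging the distal aryl-bearing group on the core is tolerated within the scatter. Compound 4 is therefore expected to give 130 nM in this assay, with a range of 55 nM to 320 nM. The step of a 1.2-fold lower number from compound 1 to compound 4 (0.06 log units; within the scatter) is expected to stay within the scatter, in no clear direction.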

Compound 4, half-maximal inhibitory concentration: 80 nM
Beside the measured number, compound 4's estimate is 1.6-fold (0.21 log units) above it; measured number inside the range.
By their numbers in this assay, from the lowest: compounds 4, 2, 3 and 1 (each within the scatter of the next).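

In this assay, benzamidomethyl in place of phenylcarbamoyl on a saturated ring carbon gives a 1.9-fold lower number from compound 1 to compound 4 (0.27 log units; within the scatter). The earlier step concerned a group on an amine nitrogen in a ring, whereas this one shows that the same tolerance extends to the saturated ring carbon of the core of compound 1: the amide can be reversed and moved out by a methylene without leaving the scatter. No supporting data bear on this result, so the step stands as an observation only.

As far as these compounds go, it remains open whether the distal amide is needed at all, since a carboxylic acid or a primary amine on this saturated ring carbon would test that directly. Also open, from the compounds shown here alone, is whether a longer chain carrying the benzamide stays within the scatter of compound 4.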